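A few compounds are considered here, and "the series" means these few. Any claim that something is new, unique, unknown or untested is made for them only; others in the source may bear on it.

Compound 1, `COc1cccc(/C=C2\CCC/C(=C\c3ccccc3Cl)C2=O)c1OC`: 11300 nM
Compound 2, `COc1cccc(/C=C2\CCC/C(=C\c3cccc(Br)c3)C2=O)c1OC`: 11700 nM
Compound 3, `COc1cccc(/C=C2\CCC/C(=C\c3ccc(O)cc3)C2=O)c1OC`: > 20000 nM

All three share one core and differ only in the aryl group on a double-bonded chain carbon bound to a double-bonded ring carbon. In a functional assay on MCF7 cells (Homo sapiens) for cytotoxicity, read by MTT assay, with a stated time of 72 h (on this read-out lower numbers stand for stronger inhibition and higher numbers for weaker inhibition), compound 1 gives 11300 nM and compound 2 gives 11700 nM, and the step of a 1.0-fold higher number from compound 1 to compound 2 (0.02 log units; within the scatter) is within the scatter. Compound 3 gives > 20000 nM, which is a limit of the assay and not a number. Accordingly the steps of an at least 1.7-fold higher number from compound 1 to compound 3 (0.24 log units; that floor lies within the scatter) and an at least 1.7-fold higher number from compound 2 to compound 3 (0.23 log units; that floor lies within the scatter) are known only as floors, and compound 3 stands at the limit of > 20000 nM in this assay, at which 1 of the 3 values shown sits.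

Compound 4, `COc1cc(/C=C2\CCC/C(=C\c3cccc(OC)c3OC)C2=O)ccc1O`, differs from compound 3 by methoxy in place of hydrogen on an aromatic carbon. For the measured compounds named here, none of the measured steps swaps methoxy for hydrogen on this ring, so the measured steps say nothing directly about its size. Because compound 3 sits at the limit of > 20000 nM in this assay, at which 1 of the 3 values shown sits, the step that the limit leaves unreadable from compound 3 to compound 4 is expected to be small and likely to end at the limit again. Compound 4 is therefore estimated at 25000 nM, with a range from 10000 nM to 60000 nM.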

Compound 4, half-maximal inhibitory concentration: 11600 nM
Beside the measured number, compound 4's estimate is 2.2-fold (0.33 log units) above it; low and high end bracket the measured number.
By their numbers in this assay, from the lowest: compounds 1, 4 and 2 (each within the scatter of the next). At a limit, above all of these: compound 3.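

Methoxy in place of hydrogen, ortho to a hydroxy group, is the first change at this position, and in this assay it brings an at least 1.7-fold lower number from compound 3 to compound 4 (0.23 log units; that floor lies within the scatter). Compound 3 remains a limit of the assay and not a number: the limit of > 20000 nM in this assay, at which 1 of the 4 values shown sits. Compound 4 keeps the hydroxy group yet gives a measured value, with a 1.0-fold lower number from compound 2 to compound 4 (0.00 log units; within the scatter) and a 1.0-fold higher number from compound 1 to compound 4 (0.01 log units; within the scatter), so the hydroxy group on this ring does not by itself hold a compound at the limit.

The true size of the step from hydrogen to methoxy cannot be read from a limit. Also open, from the compounds shown here alone, are how an amine or an ethoxy group would read at this same ring carbon, and what methoxy would do on a ring without the hydroxy group.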